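Replacing nitro with bromo in compound 1

A few compounds are considered here, and "the series" means these few. Any claim that something is new, unique, unknown or untested is made for them only; others in the source may bear on it.

For the measured compounds named here, in a functional assay on K562 cells (Homo sapiens) for inhibition (on this read-out higher numbers stand for weaker inhibition and lower numbers for stronger inhibition), three compounds have numbers so far. Compound 1 (`CC(=O)/C=C/c1ccc([N+](=O)[O-])cc1`) gives 2600 nM and compound 2 (`CC(=O)/C=C/c1ccc(F)c(Br)c1`) gives 2900 nM in this read-out, so the two lie within the scatter of each other. Compound 3 (`CC(=O)/C=C/c1cc(Br)ccc1F`) gives 5300 nM as its number, which is higher than that of compound 1 by a gap just beyond the scatter. Compound 1 thus stands level with compound 2 at the stronger end of the three.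

Going by the values given here, compound 4 (`CC(=O)/C=C/c1ccc(Br)cc1`) has no measurement yet. It keeps the core of compound 1, and the change is bromo in place of nitro on an aromatic carbon, para to a group of 5 heavy atoms (bromo in place of nitro on an aromatic carbon). Among the compounds with values here, no measured pair shows this change on its own, so the evidence is indirect. Compound 2 at 2900 nM and compound 3 at 5300 nM also carry bromo on an aromatic carbon, so numbers of this size are known with that group present. An expected 1.3-fold higher number from compound 1 to compound 4 (0.13 log units; within the scatter) would be a modest rise in the number, within the scatter. For compound 4 the estimate is 3500 nM with a range of 1800 nM to 7000 nM expected.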

Compound 4, half-maximal inhibitory concentration: 5600 nM
Compound 4: the middle estimate sits 1.6-fold (0.20 log units) below what was measured; the range from low to high includes it.
By their numbers in this assay, from the lowest: compounds 1, 2, 3 and 4 (each within the scatter of the next, the first and the last beyond it).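

For the compounds shown here, the pair gives the first direct reading of this position: in this assay, bromo in place of nitro on an aromatic carbon gives a 2.2-fold higher number from compound 1 to compound 4 (0.33 log units; beyond the scatter), a modest step that lies beyond the scatter. At this position, therefore, nitro goes with stronger inhibition than bromo, although the exchange of nitro, with 3 heavy atoms and 2 hydrogen-bond acceptors, for bromo, with 1 heavy atom and no hydrogen-bond acceptor, does not abolish inhibition. Nothing available here accounts for the step, and the reading stands as an observation on this single pair and gives no reason for it.

With only one pair at this position, the compounds shown cannot tell whether the step reflects something particular to nitro or whether bromo is the unusual member, and one exchange on one core offers no basis for a wider trend. They also leave open how an amine, a carboxylic acid or a nitrile on the same aromatic carbon would compare with nitro and bromo on the shared core.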